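The source may report more compounds than this note shows. Statements on the series, on what has been measured and on what is new or still open speak of the compounds shown alone.

Working notes on the series, a shared core carrying a varied ring on the far aromatic carbon: compound 1 is `CCC(C)(C)Cc1c[nH]c(CCc2ccc(-c3ccncc3)cc2)n1` and compound 2 is `CCC(C)(C)Cc1c[nH]c(CCc2ccc(-c3cnsc3)cc2)n1`. In a functional assay on HEK293 cells for agonist activity at Bombesin receptor subtype-3 (Homo sapiens), read by luminescence and calcium flux, with a stated time of 10 min (a higher number here means that more compound is needed for the effect, a lower number that less compound is needed), compound 1 gives 95 nM, and in this assay compound 2 gives 100 nM. For the measured compounds named here, compound 2 therefore carries the highest of the two numbers seen so far, with compound 1 the nearest neighbour; the only step between measured compounds is a 1.1-fold higher number from compound 1 to compound 2 (0.02 log units; within the scatter), so replacing pyridin-4-yl by 1,2-thiazol-4-yl did not move the number beyond the scatter.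

Compound 3, `CCC(C)(C)Cc1c[nH]c(CCc2ccc(-n3cncn3)cc2)n1`, is not yet measured. It differs from compound 2 by 1H-1,2,4-triazol-1-yl in place of 1,2-thiazol-4-yl on an aromatic carbon. Going by the values given here, the one measured step that bears on this change, a 1.1-fold higher number from compound 1 to compound 2 (0.02 log units; within the scatter), exchanged the ring on that aromatic carbon without a shift beyond the scatter. A further exchange of one five-membered aromatic ring for another at the same aromatic carbon is therefore expected to give no step beyond the scatter in this assay, in line with no change at the digits printed from compound 2 to compound 3 (within the scatter). Compound 3 is estimated at 100 nM, with a range from 40 nM to 250 nM.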

Compound 3, half-maximal effective concentration: 89 nM
Compound 3: the middle estimate sits 1.1-fold (0.05 log units) above what was measured; measured number inside the range.
By their numbers in this assay, from the lowest: compounds 3, 1 and 2 (each within the scatter of the next).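

In this assay the exchange of 1,2-thiazol-4-yl for 1H-1,2,4-triazol-1-yl stays within the scatter (a 1.1-fold lower number from compound 2 to compound 3 (0.05 log units; within the scatter)), and so does the direct exchange of pyridin-4-yl for the same triazole (a 1.1-fold lower number from compound 1 to compound 3 (0.03 log units; within the scatter)). The position para to a large group therefore takes a five-membered aromatic ring with 3 hetero atoms, joined through a ring nitrogen rather than a ring carbon, as well as the two carbon-linked rings of compounds 1 and 2, so all three steps among these compounds now lie within the scatter. No measurement is at hand that would explain this flat result.

From the compounds shown here alone, all three compounds carry an aromatic ring at this place, so it remains open whether a non-aromatic group, such as an amine or a carboxylic acid, or a plain phenyl ring would leave the number where it is. The shared core is the same throughout, and these compounds therefore say nothing about how changes to it, or to the chain it carries, would read in this assay.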